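Compound 1 to compound 4: chloro in place of ethyl

The source may hold more compounds than are shown below. What is called first, only, known or untested is meant among the compounds shown, and "the series" means these compounds.

Measured so far in an ADME assay on H1-HeLa cells (Homo sapiens) for cytotoxicity, read by MTT assay, with a stated time of 3 days (a higher number here means that more compound is tolerated, a lower number that less compound is tolerated), for three compounds:
- compound 1 `CCOC(=O)c1sc2cc(Oc3ccnc(C(=O)NC)c3)ccc2c1CC` gives 35200 nM in this series
- compound 2 `CNC(=O)c1cc(Oc2ccc3c(C)c(C(=O)OC)sc3c2)ccn1` gives 10800 nM in this series
- compound 3 `CNC(=O)c1cc(Oc2ccc3c(C)c(C(=O)O)sc3c2)ccn1` gives > 100000 nM as a limit of the assay

Of the two numerical values, compound 2 stands at 10800 nM and compound 1 at 35200 nM as the higher one, a gap beyond the scatter. The entry for compound 3 at > 100000 nM is a limit and not a number.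

Unmeasured compound 4 `CCOC(=O)c1sc2cc(Oc3ccnc(C(=O)NC)c3)ccc2c1Cl` carries chloro in place of ethyl on an aromatic carbon and otherwise keeps the core of compound 1.

Among the measured compounds shown here, the only measured step is an at least 9.2-fold higher number from compound 2 to compound 3 (0.96 log units; beyond the scatter) with hydrogen in place of methyl on an oxygen next to a carbonyl group. That step lies beyond the scatter but does not touch this aromatic carbon, so neither its size nor its direction carries over. No step beyond the scatter is therefore expected in this assay for this change, and compound 1 at 35200 nM serves as the anchor. The estimated move is a 1.2-fold lower number from compound 1 to compound 4 (0.07 log units; within the scatter) and stays within the scatter. For compound 4 the expected value is 30000 nM with an estimated range of 11000 nM to 80000 nM around it.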

Compound 4, half-maximal cytotoxic concentration: 46900 nM
The estimate for compound 4 lay 1.6-fold (0.19 log units) below the measured number; the measured number falls inside the stated range.
By their numbers in this assay, from the lowest: compound 2; then compounds 1 and 4 (each within the scatter of the next). At a limit, above all of these: compound 3.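

In this assay, chloro in place of ethyl on this aromatic carbon gives a 1.3-fold higher number from compound 1 to compound 4 (0.12 log units; within the scatter), so the two groups are not separated at this position. The earlier compounds shown here offered only a step at the oxygen next to a carbonyl group, which left this carbon unread; it now has a first reading, and it holds for the ethoxycarbonyl form of the core alone. This step can be read as a number since compound 3 alone sits at a limit, while compounds 1 and 4 do not: the limit of > 100000 nM in this assay, at which 1 of the 4 values shown sits.

Still open, going by these compounds, is whether an amine, a carboxylic acid or a longer chain such as butyl on this aromatic carbon would remain within the scatter of compounds 1 and 4, as the two groups compared here cover only a narrow part of what the position could carry. Also open, on these data alone, is whether chloro in place of the methyl group at this carbon would read the same way alongside the carboxylic acid of compound 3, since the present step comes from the ester series only.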